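The compounds below may be only part of what the source reports. "The series", "measured", "known", "first", "only" and "open" are said of these compounds alone.

Measured compounds:
compound 1, `CSc1cc(C)nc(SC)c1NC(=O)N(Cc1ccccc1)Cc1cccc(-c2ccn(C)n2)c1` — < 1 mg/kg in a functional assay on a cell-free system (plasma) with sterol O-acyltransferase, Soat (Rattus norvegicus) as the target; a lower number here means that less compound is needed, a higher number that more compound is needed for the effect
compound 2, `O=C(Nc1c(F)cc(F)cc1F)N(Cc1ccc(-c2ccsc2)cc1)C1CCCCCC1` — > 1 mg/kg
compound 3, `Cc1cc(C)c(NC(=O)N(Cc2ccc(-c3ccsc3)cc2)C2CCCCCC2)c(C)c1` — 0.51 mg/kg

Two of the three values are limits of this assay and not numbers. For compound 1 the value < 1 mg/kg is such a limit (the limit of < 1 mg/kg in this assay, at which 1 of the 3 values shown sits). For compound 2 the value > 1 mg/kg is likewise a limit (the limit of > 1 mg/kg in this assay, at which 1 of the 3 values shown sits). For the measured compounds named here, compound 3 with 0.51 mg/kg therefore holds the only number in this assay.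

Going by the values given here, the single measured step is an at least 1.9-fold lower number from compound 2 to compound 3 (0.29 log units; that floor lies within the scatter); it changes the aryl on the urea nitrogen and says nothing about the biaryl end of the benzyl group.

Compound 4, `Cc1cc(C)c(NC(=O)N(Cc2ccc(-c3ccn(C)n3)cc2)C2CCCCCC2)c(C)c1`, differs from compound 3 only there: 1-methyl-1H-pyrazol-3-yl in place of thiophen-3-yl on an aromatic carbon. Among the compounds with values here, no measured step bears on this exchange. Compound 1 carries the same 1-methyl-1H-pyrazol-3-yl on a different core and gives only a limit, so it offers no number to compare with compound 3. With nothing pointing either way, the step of a 1.0-fold lower number from compound 3 to compound 4 (0.01 log units; within the scatter) is expected to stay within the scatter. Compound 4 is estimated at 0.5 mg/kg in this assay, between 0.2 mg/kg and 1.3 mg/kg.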

Compound 4, dose for half-maximal effect: < 1 mg/kg
Compound 4 was reported as a limit (the forecaster's own chance of this, stated with the estimate: 25%); the middle value is on the limit's open side.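

In this assay, for the compounds shown here, compound 4 gives < 1 mg/kg, a limit and not a number, so no step from compound 3 to compound 4 can be read. The compounds shown leave open whether 1-methyl-1H-pyrazol-3-yl in place of thiophen-3-yl changes the number at all, and in which direction.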